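A few compounds are considered here, and "the series" means these few. Any claim that something is new, unique, unknown or untested is made for them only; others in the source may bear on it.

Measured in a functional assay on CRL2813 cells (Homo sapiens) for cytotoxicity, read by sulforhodamine B assay, with a stated time of 5 days; on this read-out higher numbers stand for weaker inhibition and lower numbers for stronger inhibition:

Compound 1 `COC(=O)c1ccc(NC(=O)N[C@H]2CC[C@H](Oc3ccc(F)cc3)CC2)cc1`: 11600 nM
Compound 2 `O=C(Nc1cccc(Cl)c1)N[C@H]1CC[C@H](Oc2ccc(F)cc2)CC1`: 5900 nM
Compound 3 `O=C(Nc1cccc(C(F)(F)F)c1)N[C@H]1CC[C@H](Oc2cccc(F)c2)CC1`: 2400 nM

Among these three numbers compound 2 stands second highest. Compound 1 gives a number close to that of compound 2, and the gap between them lies within the usual scatter, so nothing separates the two. Compound 3 gives the lowest number of the three, and its gap from compound 2 lies beyond the scatter.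

The step from compound 2 leads to compound 4 `Cc1ccccc1NC(=O)N[C@H]1CC[C@H](Oc2ccc(F)cc2)CC1`. The change is 2-methylphenyl in place of 3-chlorophenyl on an amide-type nitrogen. No pair of measured compounds in this set differs in that way alone, so the size of the step cannot be read off any shown comparison, and the three measured values give no lead on it. The expected step is a 1.4-fold higher number from compound 2 to compound 4 (0.13 log units; within the scatter), one not beyond the scatter in either direction. The estimate for compound 4 in this assay is 8000 nM, with a range from 3000 nM to 25000 nM.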

Compound 4, half-maximal inhibitory concentration: > 20000 nM
Compound 4: only a limit was reported; the forecaster's own chance of this, stated with the estimate: 10%; middle value at least 2.5-fold (0.39 log units) away from the limit.
By their numbers in this assay, from the lowest: compound 3; then compounds 2 and 1 (each within the scatter of the next). At a limit, above all of these: compound 4.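

In this assay, among the compounds shown here, 2-methylphenyl in place of 3-chlorophenyl on an amide-type nitrogen gives an at least 3.3-fold higher number from compound 2 to compound 4 (0.53 log units; beyond the scatter), the first step in this set that can be read at this position. Although the two groups have the same number of heavy atoms and neither carries a hydrogen-bond donor or acceptor, the change moves the result beyond the scatter, so this position is not indifferent to which substituted phenyl it carries. Compound 4 gives > 20000 nM, which is a limit and not a number: the limit of > 20000 nM in this assay, at which 1 of the 4 values shown sits.

What the compounds shown leave open is whether the step follows from the methyl group itself or from its place on the ring, as the two differ together here. On these data alone, it also remains open how an amine or a carboxylic acid on this phenyl ring would behave.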